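Furan-3-yl gives way to 1H-pyrrol-3-yl

A few compounds are considered here, and "the series" means these few. Any claim that something is new, unique, unknown or untested is made for them only; others in the source may bear on it.

In a functional assay on HL-60 cells (Homo sapiens) for cytotoxicity, read by XTT assay, with a stated time of 3 days (on this read-out higher numbers stand for weaker inhibition and lower numbers for stronger inhibition), compound 1 `OC[C@H]1O[C@@H](n2cc(F)c3c(-c4ccccc4)ncnc32)[C@H](O)[C@@H]1O` reaches only a limit, > 40000 nM. For the measured compounds named here, compound 2 `OC[C@H]1O[C@@H](n2cc(F)c3c(-c4ccoc4)ncnc32)[C@H](O)[C@@H]1O` gives 2000 nM, the only actual number so far. Going by the values given here, the one measured step bearing on the change, an at least 20-fold lower number from compound 1 to compound 2 (1.30 log units; beyond the scatter), is large and replaces phenyl with furan-3-yl on the same aromatic carbon. Compound 3 `OC[C@H]1O[C@@H](n2cc(F)c3c(-c4cc[nH]c4)ncnc32)[C@H](O)[C@@H]1O` differs from compound 2 by 1H-pyrrol-3-yl in place of furan-3-yl on an aromatic carbon, keeping a five-membered aromatic ring with 1 hetero atom. Given that shared ring type, only a modest shift toward stronger inhibition is expected, namely a 2.0-fold lower number from compound 2 to compound 3 (0.30 log units; within the scatter). For compound 3 the estimated value is 1000 nM, within an expected range of 150 nM to 6000 nM.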

Compound 3, half-maximal inhibitory concentration: 1900 nM
Estimate against measurement, compound 3: 1.9-fold (0.28 log units) below; low and high end bracket the measured number.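

In this assay, the exchange of furan-3-yl for 1H-pyrrol-3-yl is a step of a 1.1-fold lower number from compound 2 to compound 3 (0.02 log units; within the scatter), so on this aromatic carbon a hydrogen-bond donor in place of a hydrogen-bond acceptor shows no separable effect. A second five-membered aromatic ring now stands apart from phenyl, with an at least 21-fold lower number from compound 1 to compound 3 (1.32 log units; beyond the scatter). The value of compound 1 is a limit: the limit of > 40000 nM in this assay, at which 1 of the 3 values shown sits.

The compounds shown leave open whether thiophen-3-yl would sit at the same level as these two rings. They also leave open whether pyridin-3-yl, a six-membered ring, would behave like phenyl.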